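A few compounds are considered here, and "the series" means these few. Any claim that something is new, unique, unknown or untested is made for them only; others in the source may bear on it.

Measured in an ADME assay on L132 cells (Homo sapiens) for cytotoxicity, read by MTT assay, with a stated time of 48 h; on this read-out lower numbers stand for stronger inhibition and higher numbers for weaker inhibition:
- Compound 1 `C/C(=C\CC/C(C)=C/CC[C@@H]1[C@@]2(C)CCC(=O)C(C)(C)[C@H]2CC[C@@]1(C)O)CC/C=C(\C)C(=O)OCc1cn(-c2ccc([N+](=O)[O-])cc2)nn1`: > 150000 nM
- Compound 2 `C/C(=C\CC/C(C)=C/CC[C@@H]1[C@@]2(C)CCC(=O)C(C)(C)[C@H]2CC[C@@]1(C)O)CC/C=C(\C)C(=O)OCc1cn(-c2ccccc2[N+](=O)[O-])nn1`: > 150000 nM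
- Compound 3 `C/C(=C\CC/C(C)=C/CC[C@@H]1[C@@]2(C)CCC(=O)C(C)(C)[C@H]2CC[C@@]1(C)O)CC/C=C(\C)C(=O)OCc1cn(-c2ccccc2Br)nn1`: > 150000 nM

Each of these entries is a limit of the assay and not a number. Compound 1 therefore has no exact position on the scale, and it stands with the others at the limit of > 150000 nM in this assay, at which 3 of the 3 values shown sit.

Going by the values given here, the piece follows the move to compound 4 `C/C(=C\CC/C(C)=C/CC[C@@H]1[C@@]2(C)CCC(=O)C(C)(C)[C@H]2CC[C@@]1(C)O)CC/C=C(\C)C(=O)OCc1cn(-c2cccc(C)c2)nn1`, which has no measurement yet in this assay. Here 3-methylphenyl takes the place of 4-nitrophenyl on an aromatic nitrogen of the five-membered aromatic ring with 3 nitrogen: 3-methylphenyl in place of 4-nitrophenyl on an aromatic nitrogen.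

Two measured changes act on that same aromatic nitrogen. One is a step that the two limits leave unreadable from compound 1 to compound 2, with 2-nitrophenyl in place of 4-nitrophenyl. The other is a step that the two limits leave unreadable from compound 1 to compound 3, with 2-bromophenyl in place of 4-nitrophenyl. A third comparison, with bromo in place of nitro on an aromatic carbon, is a step that the two limits leave unreadable from compound 2 to compound 3. None of the three gives a size, yet all three compounds with a changed group on that nitrogen end at the same limit.

No step beyond the scatter is expected in either direction, and the estimate amounts to a step that the limit leaves unreadable from compound 1 to compound 4. Compound 4 is most likely to be reported at the same limit. For compound 4 the estimated value is 160000 nM, with an expected range from 80000 nM to 300000 nM.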

Compound 4, half-maximal inhibitory concentration: > 150000 nM
Compound 4 gave a limit, no number; the forecaster's own chance of this, stated with the estimate: 80%; the middle value is on the limit's open side.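

In this assay compound 4 gives > 150000 nM, which is a limit and not a number. No step to compound 4 from compound 1, compound 2 or compound 3 can be read, and all four stand together: the limit of > 150000 nM in this assay, at which 4 of the 4 values shown sit.

The compounds shown leave open whether the groups on that aromatic nitrogen differ at all in this read-out, and by how much.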